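Pyridin-4-yl for 3-methoxyphenyl: expected half-life of compound 4

A few compounds are considered here, and "the series" means these few. Any claim that something is new, unique, unknown or untested is made for them only; others in the source may bear on it.

In an ADME assay on microsomes from liver (Mus musculus) for metabolic stability, read by LC-MS, using NADPH, tested at 4.6 uM (on this read-out lower numbers stand for a shorter-lived compound and higher numbers for a longer-lived compound), compound 2 (`COc1cccc(-c2cn(C(=O)NCCCCc3ccccc3)c(=O)o2)c1`) gives 0.5 h and compound 1 (`CC(C)CNC(=O)n1cc(-c2ccccc2)oc1=O`) gives 0.833 h, two numbers within the scatter of each other. Compound 3 (`O=C(NCCCCc1ccccc1)n1cc(-c2cccnc2)oc1=O`) is reported only as a limit, > 1 h.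

Compound 4 (`O=C(NCCCCc1ccccc1)n1cc(-c2ccncc2)oc1=O`) departs from compound 2 at one place: pyridin-4-yl in place of 3-methoxyphenyl on an aromatic carbon. The group enters on an aromatic carbon, next to the ring oxygen.

Among the compounds with values here, the one measured step that bears on this is an at least 2.0-fold higher number from compound 2 to compound 3 (0.30 log units; that floor lies within the scatter), with pyridin-3-yl in place of 3-methoxyphenyl on an aromatic carbon. Its size is only a floor, set by the limit of > 1 h in this assay, at which 1 of the 3 values shown sits. Within the data shown here, no measured step yet covers pyridin-4-yl itself, so the size remains uncertain, and compound 4 may also return only a limit.

The expected step is a 2.0-fold higher number from compound 2 to compound 4 (0.30 log units; within the scatter), toward a longer-lived compound. Compound 4 is estimated at 1 h, with an expected range of 0.5 h to 2 h.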

Compound 4, half-life: > 1 h
Compound 4: a limit, no number; the forecaster's own chance of this, stated with the estimate: 50%; the middle value lies on the limit itself.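

In this assay, a second pyridine isomer on this aromatic carbon, next to the ring oxygen, gives an at least 2.0-fold higher number from compound 2 to compound 4 (0.30 log units; that floor lies within the scatter). Compound 4 gives > 1 h, which is a limit and not a number. The step between the two pyridine isomers cannot be read, and this read-out does not separate pyridin-4-yl from pyridin-3-yl at this position: the limit of > 1 h in this assay, at which 2 of the 4 values shown sit.

Going by these compounds, how far the half-lives of compound 3 and compound 4 extend past the limit remains open, as does whether either replacement of 3-methoxyphenyl exceeds the scatter. Also open, on these data alone, is how pyridin-2-yl, or a phenyl ring bearing a carboxylic acid or an amine, would read on this carbon.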